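The source may report more compounds than this note shows. Statements on the series, on what has been measured and on what is new or still open speak of the compounds shown alone.

Working notes on the series. The shared core is that of compound 1 `Cn1ncnc1-c1cc(Oc2ccc(NC(=O)N/N=C/c3ccccc3)cc2F)ccn1` and compound 3 `Cn1cnnc1-c1cc(Oc2ccc(NC(=O)N/N=C/c3ccccc3)cc2F)ccn1`. In a functional assay on U-87MG ATCC cells (Homo sapiens) for cytotoxicity, read by MTT assay, with a stated time of 72 h (on this read-out lower numbers stand for stronger inhibition and higher numbers for weaker inhibition), compound 1 returns only the assay limit > 100000 nM. Compound 3 gives 36300 nM; the change is an at least 2.7-fold lower number from compound 1 to compound 3 (0.44 log units; beyond the scatter). Compound 2 `CN(C)CCn1cnnc1-c1cc(Oc2ccc(NC(=O)N/N=C/c3ccc(O)c(O)c3)cc2F)ccn1` also returns only the limit > 100000 nM in this assay. On the numbers shown compound 2 has no fixed place: this assay shows (the limit of > 100000 nM in this assay, at which 2 of the 3 values shown sit). Compound 4 `Cc1cc(/C=N/NC(=O)Nc2ccc(Oc3ccnc(-c4nncn4CCN(C)C)c3)c(F)c2)cc(C)c1O` differs from compound 2 by 4-hydroxy-3,5-dimethylphenyl in place of 3,4-dihydroxyphenyl on a carbon with a double bond to nitrogen. For the measured compounds named here, no measured step touches this change; the single measured step concerns 4-methyl-4H-1,2,4-triazol-3-yl against 1-methyl-1H-1,2,4-triazol-5-yl. With compound 2 itself a limit, no step beyond the scatter is expected in either direction for a number no higher from compound 2 to compound 4 (the limit leaves the size open), and a further limit is likely. Compound 4 is estimated at 100000 nM (range 30000 nM to 300000 nM).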

Compound 4, half-maximal inhibitory concentration: 7710 nM
Estimate against measurement, compound 4: 13-fold (1.11 log units) above; the measured number lies below the stated range.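

At the carbon with a double bond to nitrogen, 4-hydroxy-3,5-dimethylphenyl in place of 3,4-dihydroxyphenyl gives, in this assay, an at least 12-fold lower number from compound 2 to compound 4 (1.11 log units; beyond the scatter). For the compounds shown here, this is the first measured step at this place, as the earlier step concerned only the triazole, and it shows that this position can shift the read-out well beyond the scatter. The full size of the step stays open: the limit of > 100000 nM in this assay, at which 2 of the 4 values shown sit.

The methyl groups entering and the hydroxy group leaving are not separated by this change. On these data alone, how a 4-methoxyphenyl or 4-aminophenyl group would read at the same place also remains open.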